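Compound 1 and the Piperazine Nitrogen: Phenyl to Ethyl

The source may hold more compounds than are shown below. What is called first, only, known or untested is meant among the compounds shown, and "the series" means these compounds.

Among the three compounds measured so far, compound 1 `Cc1n[nH]c(C)c1Oc1c(O)cc(O)c2c(=O)cc(-c3ccc(N4CCN(c5ccccc5)CC4)cc3)oc12` stands lowest in an assay on cells for inhibition of ubiquitin carboxyl-terminal hydrolase 8 (Homo sapiens), read by fluorescence, with a stated time of 30 min; a higher number here means a weaker inhibitor, a lower number a stronger inhibitor: in that assay compound 1 gives 3500 nM. Compound 2 `COc1c(O)cc(O)c2c(=O)cc(-c3ccc(N4CCCNCC4)cc3)oc12` carries a methoxy group and a 1,4-diazepan-1-yl ring in place of the groups of compound 1. In this assay compound 2 gives 31600 nM. Compound 3 `COc1c(O)cc(O)c2c(=O)cc(-c3ccc(N4CCCC4)cc3)oc12`, with a pyrrolidin-1-yl ring on the same aromatic carbon, gives 16200 nM in this assay. Within the data shown here, the only single-point step available, a 2.0-fold lower number from compound 2 to compound 3 (0.29 log units; within the scatter), exchanges one amine ring for another and stays within the scatter. Compound 1 thus lies well below both, by more than the scatter in each case.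

Compound 4 `CCN1CCN(c2ccc(-c3cc(=O)c4c(O)cc(O)c(Oc5c(C)n[nH]c5C)c4o3)cc2)CC1` differs from compound 1 by ethyl in place of phenyl on an amine nitrogen in a ring. Among the measured compounds shown here, no measured pair alters the group on the piperazine nitrogen, so the step of a 2.0-fold lower number from compound 2 to compound 3 (0.29 log units; within the scatter) is the nearest guide: a change of the amine portion that left this assay essentially unmoved. On that basis the expected step of a 1.4-fold higher number from compound 1 to compound 4 (0.15 log units; within the scatter) is small, with no clear direction beyond the scatter. Compound 4 is therefore estimated to give 5000 nM in this assay, within a range from 1500 nM to 16000 nM.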

Compound 4, half-maximal inhibitory concentration: 15500 nM
For compound 4 the middle estimate is 3.1-fold (0.49 log units) below the measured one; the measured number falls inside the stated range.
By their numbers in this assay, from the lowest: compound 1; then compounds 4, 3 and 2 (each within the scatter of the next, the first and the last beyond it).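

Among these compounds, the step from phenyl to ethyl is the first one at this position, on an amine nitrogen in a ring, and in this assay it reads a 4.4-fold higher number from compound 1 to compound 4 (0.65 log units; beyond the scatter). Among the compounds shown here, the earlier exchange of one amine ring for another, a 2.0-fold lower number from compound 2 to compound 3 (0.29 log units; within the scatter), stayed within the scatter, so this pair is the first to show the number responding to a change in the amine portion, and here 4-phenylpiperazin-1-yl gives the lower number of the two groups compared. Nothing at hand explains why the step runs in this direction.

With a single pair, the compounds shown leave open whether the lower number goes with the six-membered aromatic ring of carbon only or simply with the larger group, a question that a cyclohexyl ring, a benzyl group or a pyridinyl ring on the same nitrogen would address. They also leave open how far the number moves with a bare hydrogen or a methyl group on that nitrogen, and whether the step keeps its size when the rest of the molecule changes.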